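This account rests on a few compounds, and the source may have more. Where it says the series, first, only, none or still open, it means among the compounds named here.

Compound 1 `CCCCCCCCOc1nc(N)nc2c1ncn2/C=C1/CC1(CO)CO` in an ADME assay on MOLT-3 cells (Homo sapiens) for cytotoxicity, with a stated time of 7 days (a lower number here means that less compound is tolerated, a higher number that more compound is tolerated), gives > 20000 nM, which is a limit of the assay. Compound 2 `Nc1nc(OCc2ccccc2)c2ncn(/C=C3/CC3(CO)CO)c2n1` gives > 20000 nM, also a limit. Compound 3 `CSc1nc(N)nc2c1ncn2/C=C1/CC1(CO)CO` gives > 20000 nM, again a limit.

For the measured compounds named here, compound 3 therefore stands at the limit (the limit of > 20000 nM in this assay, at which 3 of the 3 values shown sit), where every measured value sits; no compound shows a number. The steps a step that the two limits leave unreadable from compound 1 to compound 2, a step that the two limits leave unreadable from compound 1 to compound 3 and a step that the two limits leave unreadable from compound 2 to compound 3 cannot be read from these limits. Compound 4 `CCCCSc1nc(N)nc2c1ncn2/C=C1/CC1(CO)CO` differs from compound 3 by propyl in place of hydrogen on a saturated chain carbon bound to a sulfur. Going by the values given here, no measured step bears directly on this change, and the measured steps, all unreadable, give no size or direction. No step beyond the scatter is expected. Compound 4 is expected to give 25000 nM, between 8000 nM and 80000 nM, most likely again as a limit. The expected step is a step that the limit leaves unreadable from compound 3 to compound 4.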

Compound 4, half-maximal cytotoxic concentration: > 20000 nM
Compound 4 gave a limit, no number; the forecaster's own chance of this, stated with the estimate: 75%; the middle value lies beyond the limit too.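

Compound 4 gives > 20000 nM, a limit and not a number, so the steps joining compound 4 to compound 1, compound 2 and compound 3 cannot be read. The compounds shown leave open whether any of these changes alters the read-out in this assay, as all of them sit at one limit: the limit of > 20000 nM in this assay, at which 4 of the 4 values shown sit.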